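Working notes: aryl change from compound 3 to compound 4

The compounds below may be only part of what the source reports. "The series", "measured", "known", "first", "only" and "open" are said of these compounds alone.

Measured in a functional assay on MCF7 cells (Homo sapiens) for antiproliferative activity, read by MTT assay, with stated times of 24 h and 72 h; on this read-out lower numbers stand for stronger inhibition and higher numbers for weaker inhibition:
compound 1 `COc1cc([C@@H]2[C@H](Oc3ccccc3)C(=O)N2c2cc(OC)c(OC)c(OC)c2)cc(OC)c1OC`: 29000 nM
compound 2 `COc1cc(N2C(=O)[C@@H](Oc3ccccc3)[C@H]2c2ccc3ccccc3c2)cc(OC)c1OC`: 282000 nM
compound 3 `COc1cc(N2C(=O)[C@@H](Oc3ccccc3)[C@H]2c2cccc(O)c2)cc(OC)c1OC`: 54000 nM

Two steps fix the position of compound 3: a 1.9-fold higher number from compound 1 to compound 3 (0.27 log units; within the scatter) and a 5.2-fold lower number from compound 2 to compound 3 (0.72 log units; beyond the scatter). It therefore cannot be separated from the 3,4,5-trimethoxyphenyl member but stands apart from the naphthalen-2-yl member.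

Compound 4 `COc1cc(N)c([C@@H]2[C@H](Oc3ccccc3)C(=O)N2c2cc(OC)c(OC)c(OC)c2)cc1O` differs from it at one place: a group of 10 heavy atoms (7 carbon, 1 nitrogen, 2 oxygen; one six-membered aromatic ring of carbon only) in place of a group of 7 heavy atoms (6 carbon, 1 oxygen; one six-membered aromatic ring of carbon only), on a saturated ring carbon. All three measured steps concern this same place, and the widest is a 9.7-fold higher number from compound 1 to compound 2 (0.99 log units; beyond the scatter). None involves a group containing nitrogen, so the guidance is limited. Compound 4 keeps an oxygen-bearing aromatic ring, as compound 1 and compound 3 do, whereas compound 2 does not. A modest step to a lower number is expected in this assay, comparable in size to a 5.2-fold lower number from compound 2 to compound 3 (0.72 log units; beyond the scatter), with low confidence in its direction. The expected step is a 6.8-fold lower number from compound 3 to compound 4 (0.83 log units; beyond the scatter). For compound 4 the estimated value is 8000 nM, with an expected range of 300 nM to 60000 nM.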

Compound 4, half-maximal inhibitory concentration: 20000 nM
The estimate for compound 4 lay 2.5-fold (0.40 log units) below the measured number, and the stated range covers the measured number.
By their numbers in this assay, from the lowest: compounds 4, 1 and 3 (each within the scatter of the next, the first and the last beyond it); then compound 2.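

Compound 4 is the first member shown with nitrogen in the aryl group on the saturated ring carbon, and in this assay the change gives a 2.7-fold lower number from compound 3 to compound 4 (0.43 log units; beyond the scatter) and a 14-fold lower number from compound 2 to compound 4 (1.15 log units; beyond the scatter), so a nitrogen-bearing aryl group is compatible with activity at this position. Against the 3,4,5-trimethoxyphenyl member, the change gives a 1.5-fold lower number from compound 1 to compound 4 (0.16 log units; within the scatter), so these two aryl groups cannot be separated on this read-out. Nothing available gives a reason for these steps.

The compounds shown leave open which part of the entering group carries the step from the 3-hydroxyphenyl member, as its nitrogen and oxygen atoms enter together in a single change. Going by these compounds, how a carboxylic acid or a nitrile on this aryl ring would read also remains open.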